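Replacing 2-hydroxyphenyl with furan-2-yl in compound 4

The source may hold more compounds than are shown below. What is called first, only, known or untested is meant among the compounds shown, and "the series" means these compounds.

In a functional assay on MCF7 cells (Homo sapiens) for cytotoxicity, read by MTT assay, with a stated time of 48 h (a higher number here means a weaker inhibitor, a lower number a stronger inhibitor), compound 1 `NNC(=O)CSc1nnc(-c2ccncc2)o1` gives 3260 nM, compound 2 `O=C(CSc1nnc(-c2ccncc2)o1)N/N=C/c1ccc(Br)cc1` gives 19100 nM and compound 3 `O=C(CSc1nnc(-c2ccncc2)o1)N/N=C/c1ccccc1O` gives 4750 nM. Compound 3 thus lies within the scatter of compound 1 and clearly under the number of compound 2. Compound 4 `O=C(CSc1nnc(-c2ccncc2)o1)N/N=C/c1ccco1` differs from compound 3 by one change, furan-2-yl in place of 2-hydroxyphenyl on a carbon with a double bond to nitrogen. Going by the values given here, the only measured step at this place is modest, a 4.0-fold lower number from compound 2 to compound 3 (0.60 log units; beyond the scatter), and no furan-2-yl compound has a value yet. A small step in this assay towards a higher number is therefore expected, a 1.4-fold higher number from compound 3 to compound 4 (0.14 log units; within the scatter), probably within the scatter. Compound 4 is estimated at 6500 nM, with an expected range from 2500 nM to 16000 nM.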

Compound 4, half-maximal inhibitory concentration: 16600 nM
Compound 4: the middle estimate sits 2.6-fold (0.41 log units) below what was measured; measured number outside the range, above it.
By their numbers in this assay, from the lowest: compounds 1 and 3 (each within the scatter of the next); then compounds 4 and 2 (each within the scatter of the next).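

In this assay, the furan-2-yl group does not keep the lower number of 2-hydroxyphenyl (a 3.5-fold higher number from compound 3 to compound 4 (0.54 log units; beyond the scatter)) and instead stands level with 4-bromophenyl (a 1.2-fold lower number from compound 2 to compound 4 (0.06 log units; within the scatter)), so among these three groups on the carbon with a double bond to nitrogen, only 2-hydroxyphenyl stands apart. Adding the furan-2-yl group on the amide-type nitrogen of compound 1 also gives a clearly higher number (a 5.1-fold higher number from compound 1 to compound 4 (0.71 log units; beyond the scatter)). Nothing measured on these compounds gives a reason for these differences. From the compounds shown here alone, it remains open whether the lower number goes with the hydroxyl or with the six-membered ring of 2-hydroxyphenyl, which an unsubstituted phenyl or a 2-methoxyphenyl group at this place would help to separate.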